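A few compounds are considered here, and "the series" means these few. Any claim that something is new, unique, unknown or untested is made for them only; others in the source may bear on it.

Compound 1 `CC[C@@H]1NC(=O)[C@H](CCCNC(=N)N)NC(=O)[C@](C)(NC(=O)C(C)C)CCCCN(C)C(=O)[C@@H](c2ccc(Cl)cc2)NC1=O` is the starting point of this step. In an ADME assay on microsomes (Rattus norvegicus) for metabolic stability (a higher number here means that the compound lasts longer, a lower number that the compound disappears faster), compound 1 gives > 1 h, which is a limit of the assay rather than a number. Compound 3 `CC[C@@H]1NC(=O)[C@H](CCCNC(=N)NC)NC(=O)[C@](C)(NC(=O)C(C)C)CCCCCCNC(=O)[C@@H](c2ccccc2)NC1=O` is in the same situation: in this assay compound 3 gives > 1 h, again a limit. Going by the values given here, compound 2 `CCC(CC)(NC(=O)C(C)C)C(=O)N[C@@H](CCCNC(=N)N)C(=O)NC1(C(=O)NC(c2ccccc2)c2ccccc2)CCCC1` is the one compound of the three with a number in this assay, where compound 2 gives 0.567 h. So compound 1 stands at the limit of > 1 h in this assay, at which 2 of the 3 values shown sit, and no measured step involving compound 1 can be drawn from these values.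

Compound 4 `CC[C@@H]1NC(=O)[C@H](CCCNC(=N)N)NC(=O)[C@](C)(NC(=O)C(C)C)CCCCN(C)C(=O)[C@@H](c2ccccc2)NC1=O` differs from compound 1 in one place: hydrogen in place of chloro on an aromatic carbon. Among the compounds with values here, no pair of measured compounds differing in only one place is available, so the size of this step has to be guessed. The author expects the step that the limit leaves unreadable from compound 1 to compound 4 to stay within the scatter of repeated measurements. Compound 4 is therefore estimated at 1.1 h in this assay, with a range from 0.5 h to 2.5 h.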

Compound 4, half-life: > 1 h
Compound 4 gave a limit, no number (the forecaster's own chance of this, stated with the estimate: 55%); the middle value is on the limit's open side.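

No step can be read from compound 1 to compound 4, because each gives a limit rather than a number: the limit of > 1 h in this assay, at which 3 of the 4 values shown sit.

The compounds shown leave open whether 4-chlorophenyl to phenyl changes the half-life in this assay at all, and how far beyond the limit compound 1 and compound 4 lie.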